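A few compounds are considered here, and "the series" means these few. Any claim that something is new, unique, unknown or untested is made for them only; others in the source may bear on it.

Measured compounds:
- compound 1, `CCOC(=O)Nc1ccc(S(=O)(=O)N2C(=O)N[C@@H](c3ccccc3)C2C)cc1Cl`: 5500 nM
- compound 2, `CCc1cc(S(=O)(=O)N2C[C@H](c3ccccc3)NC2=O)ccc1NC(=O)c1ccc([N+](=O)[O-])cc1`: 500 nM
- compound 3, `CCc1cc(S(=O)(=O)N2C[C@H](c3ccccc3)NC2=O)ccc1NC(=O)OC(C)C`: 60 nM

In a functional assay on HCT-116 cells (Homo sapiens) for cytotoxicity, read by MTT assay (on this read-out lower numbers stand for stronger inhibition and higher numbers for weaker inhibition), compound 1 gives the highest of the three numbers; its nearest neighbour is compound 2, and compound 3 lies furthest below it. Among the measured compounds shown here, the one measured step, an 8.3-fold lower number from compound 2 to compound 3 (0.92 log units; beyond the scatter), concerns the group on the carbonyl carbon of the side chain and says nothing directly about the change studied here.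

Compound 4, `CCOC(=O)Nc1ccc(S(=O)(=O)N2C[C@H](c3ccccc3)NC2=O)cc1Cl`, differs from compound 1 in a single place: hydrogen in place of methyl on a saturated ring carbon. The change is on the saturated ring carbon next to the ring nitrogen, the position where compounds 2 and 3 already carry only hydrogen. For the measured compounds named here, no measured pair isolates this change, so the expectation rests on the closest relative of compound 4 with the same core, compound 3, which gives 60 nM; compound 4 still carries the ethoxycarbonyl and chloro groups rather than those of compound 3. A step toward a lower number, beyond the scatter, is expected: an 18-fold lower number from compound 1 to compound 4 (1.26 log units; beyond the scatter). Compound 4 is therefore estimated at 300 nM, within the range 60 nM to 1500 nM.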

Compound 4, half-maximal inhibitory concentration: 200 nM
Estimate against measurement, compound 4: 1.5-fold (0.18 log units) above, and the stated range covers the measured number.
By their numbers in this assay, from the lowest: compound 3; then compound 4; then compound 2; then compound 1.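

In this assay, among the compounds shown here, the pair gives a 28-fold lower number from compound 1 to compound 4 (1.44 log units; beyond the scatter) and isolates this saturated ring carbon for the first time, since the rest of compound 1 and compound 4 is the same. The step is large for so small an edit, with the loss of a single carbon atom as methyl gives way to hydrogen, so this position is not indifferent to what it carries. Nothing available explains why the number falls so far when the methyl goes.

Going by these compounds, whether an ethyl, a hydroxymethyl or a fluorine on this carbon would sit closer to the methyl or to the hydrogen remains open. It is also unknown whether a methyl here would raise the number to a similar extent with the side chains of compound 2 and compound 3, which carry only hydrogen at this carbon.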